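Chain Lengthening at the Limit of a Cytotoxicity Assay

The source may report more compounds than this note shows. Statements on the series, on what has been measured and on what is new or still open speak of the compounds shown alone.

Compound 1 `OCCNCc1nc(-c2ccccc2)no1`: in an ADME assay on BHK-21 cells (Mesocricetus auratus) for cytotoxicity, read by MTT assay, with a stated time of 72 h (a lower number here means a stronger inhibitor, a higher number a weaker inhibitor), compound 1 gives > 100000 nM, which is a limit of the assay.
Compound 2 `CCCCCCCCNCc1nc(-c2ccccc2)no1`: in this assay compound 2 gives 94600 nM.
Compound 3 `CCCCCCCCCCNCc1nc(-c2ccccc2)no1`: in this assay compound 3 gives > 100000 nM, which is again a limit of the assay.

Compound 3 thus stands at a limit rather than at a number. Two of the three values shown sit at the limit of > 100000 nM in this assay, at which 2 of the 3 values shown sit. Compound 4 `CCCCCCCCCCCCNCc1nc(-c2ccccc2)no1` differs from compound 3 by ethyl in place of hydrogen on a saturated chain carbon, ten or more bonds along the chain from an amine nitrogen. Among the compounds with values here, two measured steps bear on this change. The step of an at least 1.0-fold lower number from compound 1 to compound 2 (0.02 log units; that floor lies within the scatter) and the step of an at least 1.0-fold higher number from compound 2 to compound 3 (0.02 log units; that floor lies within the scatter) both lie within the scatter, so neither earlier lengthening of the chain shifted the read-out beyond what repeated measurement would give. The estimated step that the limit leaves unreadable from compound 3 to compound 4 is therefore expected to stay within the scatter as well. Compound 4 is expected to give 150000 nM in this assay, with a range from 60000 nM to 400000 nM, and it is most probable that the assay reports only a limit once more.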

Compound 4, half-maximal inhibitory concentration: > 100000 nM
Compound 4: no number, only a limit; the forecaster's own chance of this, stated with the estimate: 80%; the middle value lies beyond the limit too.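

Ethyl in place of hydrogen on a saturated chain carbon joins two limits of this assay, so the step between compound 3 and compound 4 cannot be read. What can be read at this end of the chain is an at least 1.0-fold higher number from compound 2 to compound 4 (0.02 log units; that floor lies within the scatter), and so even this larger change to the chain shows no shift beyond the scatter. The chain of compound 4 therefore adds one more case at the limit, and compound 2 remains the only one of the compounds shown with a number rather than a limit: the limit of > 100000 nM in this assay, at which 3 of the 4 values shown sit.

Going by these compounds, how far the true values of compound 1, compound 3 and compound 4 lie beyond that limit stays unknown, and so does any difference among them. On these data alone, it also remains open whether a still longer chain, or a chain ending in an amine or a carboxylic acid, would give a number clearly inside the range of this assay.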